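This account rests on a few compounds, and the source may have more. Where it says the series, first, only, none or still open, it means among the compounds named here.

In a functional assay on HCT-116 cells (Homo sapiens) for antiproliferative activity, read by MTT assay, with a stated time of 72 h (a higher number here means a weaker inhibitor, a lower number a stronger inhibitor), compound 3 `CN(c1ccc2[nH]c(-c3n[nH]c4ccccc34)cc2n1)S(=O)(=O)c1ccc(Cl)cc1` gives 5980 nM, the lowest of the three numbers: compound 2 `CN(c1ccc2[nH]c(-c3n[nH]c4ccccc34)cc2n1)S(=O)(=O)c1ccccc1` gives 6740 nM, and a 1.1-fold lower number from compound 2 to compound 3 (0.05 log units; within the scatter); compound 1 `COc1ccc(C(=O)N(C)c2ccc3[nH]c(-c4n[nH]c5ccccc45)cc3n2)cc1` gives 29500 nM, and a 4.9-fold lower number from compound 1 to compound 3 (0.69 log units; beyond the scatter). Compound 4 `CN(C(=O)Nc1ccccc1)c1ccc2[nH]c(-c3n[nH]c4ccccc34)cc2n1` differs from compound 3 by phenylcarbamoyl in place of (4-chlorophenyl)sulfonyl on a nitrogen on an aromatic ring. The measured steps that bear on this exchange are a 4.4-fold lower number from compound 1 to compound 2 (0.64 log units; beyond the scatter) and a 4.9-fold lower number from compound 1 to compound 3 (0.69 log units; beyond the scatter), both replacing an aryl carbonyl on that nitrogen with an aryl sulfonyl, while a 1.1-fold lower number from compound 2 to compound 3 (0.05 log units; within the scatter). Compound 4 puts a carbonyl back onto that nitrogen, so in this assay its number is expected to rise toward compound 1 because a 4.9-fold lower number from compound 1 to compound 3 (0.69 log units; beyond the scatter) ran the other way. The expected step is a 2.5-fold higher number from compound 3 to compound 4 (0.40 log units; beyond the scatter). For compound 4 the estimated value is 15000 nM, within a range of 5000 nM to 45000 nM.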

Compound 4, half-maximal inhibitory concentration: 1.3 nM
The estimate for compound 4 lay 12000-fold (4.06 log units) above the measured number, and the stated range ends above it.
By their numbers in this assay, from the lowest: compound 4; then compounds 3 and 2 (each within the scatter of the next); then compound 1.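

On the nitrogen on an aromatic ring, phenylcarbamoyl separates sharply from the sulfonyl groups in this assay, with a 4600-fold lower number from compound 3 to compound 4 (3.66 log units; beyond the scatter) and a 5200-fold lower number from compound 2 to compound 4 (3.71 log units; beyond the scatter). A carbonyl on this nitrogen does not by itself set the number: anilino in place of 4-methoxyphenyl on the carbonyl carbon gives a 23000-fold lower number from compound 1 to compound 4 (4.36 log units; beyond the scatter), so what the carbonyl carries decides the outcome here. No available measurement explains these steps.

As far as these compounds go, it remains open whether the step depends on the amide hydrogen of phenylcarbamoyl, and whether a benzyl or cyclohexyl group in place of its phenyl ring would hold the number.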